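The source may report more compounds than this note shows. Statements on the series, on what has been measured and on what is new or still open speak of the compounds shown alone.

Compound 1 `COC(=O)c1cc(N2C(=O)C3=C(CCCC3)C2=O)ccc1Cl`: 1780 nM
Compound 2 `COC(=O)c1cc(N2C(=O)C3=C(CCCC3)C2=O)c(F)cc1Cl`: 67.6 nM
Compound 3 `CCCCOC(=O)c1cc(N2C(=O)C3=C(CCCC3)C2=O)ccc1Cl`: 6310 nM

All three were tested in a functional assay on the whole organism for inhibition, with Scenedesmus acutus as the target; a lower number here means a stronger inhibitor, a higher number a weaker inhibitor. Compound 2 gives the lowest number of the three: a 26-fold lower number from compound 1 to compound 2 (1.42 log units; beyond the scatter), and compound 3 lies further off still. Compound 4 `C#CCOc1cc(N2C(=O)C3=C(CCCC3)C2=O)c(F)cc1Cl` has not yet been measured in this assay. It differs from compound 2 in one place: propargyloxy in place of methoxycarbonyl on an aromatic carbon. Going by the values given here, no measured step swaps this group for another. Among the compounds with values here, the only step that touches the same group is a 3.5-fold higher number from compound 1 to compound 3 (0.55 log units; beyond the scatter), a modest weakening, and it does not remove the methoxycarbonyl group, so it only loosely bears on the present change. Compound 4 is therefore expected to give 200 nM, within 30 nM to 1500 nM. The expected step is a 3.0-fold higher number from compound 2 to compound 4 (0.47 log units; beyond the scatter), a weakening beyond the scatter but with wide uncertainty.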

Compound 4, half-maximal inhibitory concentration: 15.9 nM
Beside the measured number, compound 4's estimate is 13-fold (1.10 log units) above it; measured number outside the range, below it.
By their numbers in this assay, from the lowest: compound 4; then compound 2; then compound 1; then compound 3.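

Replacing methoxycarbonyl with propargyloxy, on the aromatic carbon ortho to a chloro group, gives a 4.3-fold lower number from compound 2 to compound 4 (0.63 log units; beyond the scatter) in this assay. The earlier step changed only the chain on the ester oxygen, whereas this one shows that the whole methoxycarbonyl group can leave this position without any loss of inhibition. Nothing available explains why the number falls.

The compounds shown leave open whether the triple bond matters, which a propoxy group would test. As far as these compounds go, it also remains open how an amine or a carboxylic acid would fare at this position.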